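Trimming the tail of a long-chain urea

The source may hold more compounds than are shown below. What is called first, only, known or untested is meant among the compounds shown, and "the series" means these compounds.

Compounds measured so far:
compound 1, `CCCc1ccc(NC(=O)Nc2c(C(C)C)cccc2C(C)C)cc1`, 38 nM
compound 2, `CCCCCCCc1ccc(NC(=O)Nc2c(C(C)C)cccc2C(C)C)cc1`, 19 nM
compound 3, `CCCCCCCCCCCCc1ccc(NC(=O)Nc2c(C(C)C)cccc2C(C)C)cc1`, 15 nM

These three share one core and differ only in the length of a straight chain on the far ring. In an assay on isolated protein for inhibition of acyl-CoA:cholesterol acyltransferase (Oryctolagus cuniculus) (a lower number here means a stronger inhibitor, a higher number a weaker inhibitor), compound 3 gives the lowest number of the three. Its nearest neighbour is compound 2, with a 1.3-fold lower number from compound 2 to compound 3 (0.10 log units; within the scatter), so the two cannot be told apart. Compound 1 stands further away, with a 2.5-fold lower number from compound 1 to compound 3 (0.40 log units; beyond the scatter), a modest gap.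

Compound 4, `CCCCCCCCCCCc1ccc(NC(=O)Nc2c(C(C)C)cccc2C(C)C)cc1`, is the next step: hydrogen in place of methyl on a saturated chain carbon, ten or more bonds along the chain from an aromatic carbon. In short, the chain of compound 3 loses one carbon at its far end.

The steps that speak to this are the lengthening steps already seen. Adding butyl, a 2.0-fold lower number from compound 1 to compound 2 (0.30 log units; within the scatter), and adding pentyl, a 1.3-fold lower number from compound 2 to compound 3 (0.10 log units; within the scatter), both stayed within the scatter; only the combined change, a 2.5-fold lower number from compound 1 to compound 3 (0.40 log units; beyond the scatter), reached beyond it. Removing a single carbon at the end of an already long chain is a smaller change than any of those, so no step beyond the scatter is expected in this assay, in either direction. Compound 4 is therefore estimated at 17 nM, within 8 nM to 36 nM, which means an expected step of a 1.1-fold higher number from compound 3 to compound 4 (0.05 log units; within the scatter).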

Compound 4, half-maximal inhibitory concentration: 9 nM
For compound 4 the middle estimate is 1.9-fold (0.28 log units) above the measured one; the measured number falls inside the stated range.
By their numbers in this assay, from the lowest: compounds 4, 3, 2 and 1 (each within the scatter of the next, the first and the last beyond it).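

Taking away the methyl and leaving hydrogen on this saturated chain carbon gives a step that stays within the scatter in this assay (a 1.7-fold lower number from compound 3 to compound 4 (0.22 log units; within the scatter)), so compound 3 and compound 4 cannot be told apart and the loss of this one carbon costs nothing measurable. For the compounds shown here, the new chain also adds a comparison that compound 3 could not supply: compound 4 stands clearly apart from the mid-length chain (a 2.1-fold lower number from compound 2 to compound 4 (0.32 log units; beyond the scatter)), a modest step beyond the scatter, while its distance from the shortest chain is the widest of the series so far (a 4.2-fold lower number from compound 1 to compound 4 (0.63 log units; beyond the scatter)), though still modest. Nothing shown here explains these numbers.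

Chains of intermediate length, between those of compound 2 and compound 4, would show where the separation from compound 2 sets in, and a longer chain than that of compound 3 would show whether the numbers stay this low. Also open, from the compounds shown here alone, is whether a carboxylic acid or an amine in place of this methyl would be tolerated in the same way as hydrogen.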